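Sulfonamide Nitrogen Substituents on a Thiourea Scaffold

The source may hold more compounds than are shown below. What is called first, only, known or untested is meant among the compounds shown, and "the series" means these compounds.

Measured compounds:
compound 1 `NS(=O)(=O)c1ccc(N/C(S)=N\c2ccnc3cc(C(F)(F)F)ccc23)cc1`: 52200 nM
compound 2 `O=S(=O)(Nc1ccccn1)c1ccc(N/C(S)=N\c2ccnc3cc(C(F)(F)F)ccc23)cc1`: 28000 nM

Two compounds share the core of compound 1 and were tested in a functional assay on HepG2 cells (Homo sapiens) for antiproliferative activity, read by sulforhodamine B assay, with a stated time of 48 h; a higher number here means a weaker inhibitor, a lower number a stronger inhibitor. Compound 1 carries a free sulfonamide nitrogen and gives 52200 nM, the highest of the two numbers. Compound 2 gives 28000 nM; the step of a 1.9-fold lower number from compound 1 to compound 2 (0.27 log units; within the scatter) does not separate the two compounds.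

Compound 3 `O=S(=O)(Nc1ncccn1)c1ccc(N/C(S)=N\c2ccnc3cc(C(F)(F)F)ccc23)cc1` is not yet measured. Compared with compound 1, the change is pyrimidin-2-yl in place of hydrogen on a sulfonamide nitrogen.

Within the data shown here, the only step that bears on this change is the one from compound 1 to compound 2, which also placed a six-membered aromatic ring on the sulfonamide nitrogen and stayed within the scatter. With a pyrimidin-2-yl entering at the same place, no step beyond the scatter is expected for compound 3 in this assay; if anything, a modest move toward the lower number of compound 2 is expected, as a 1.6-fold lower number from compound 1 to compound 3 (0.21 log units; within the scatter). Compound 3 is therefore estimated at 32000 nM, with a range from 13000 nM to 80000 nM.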

Compound 3, half-maximal inhibitory concentration: 42100 nM
Compound 3: middle estimate off by 1.3-fold (0.12 log units), on the low side; low and high end bracket the measured number.
By their numbers in this assay, from the lowest: compounds 2, 3 and 1 (each within the scatter of the next).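

In this assay, a second ring on the sulfonamide nitrogen, pyrimidin-2-yl, also fails to separate from the free sulfonamide (a 1.2-fold lower number from compound 1 to compound 3 (0.09 log units; within the scatter)), so the earlier result for pyridin-2-yl is no longer a single case: across the three compounds shown, neither six-membered aromatic ring at this place gives a step beyond the scatter. The new compound also allows a direct exchange of one ring for the other on the same nitrogen (a 1.5-fold higher number from compound 2 to compound 3 (0.18 log units; within the scatter)), and this step, which the earlier pair could not offer, shows that the number does not distinguish pyridin-2-yl from pyrimidin-2-yl at this position. Nothing available accounts for these numbers or explains why the three compounds stay so close.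

As far as these compounds go, whether a methyl, an acetyl or a thiazol-2-yl on the sulfonamide nitrogen would move the number beyond the scatter remains open, as does the effect of an amine or a carboxylic acid on the pyrimidin-2-yl ring. All three compounds vary at this nitrogen alone, so the compounds shown also leave open how changes elsewhere on the shared core would read in this assay.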